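A few compounds are considered here, and "the series" means these few. Any claim that something is new, unique, unknown or untested is made for them only; others in the source may bear on it.

Working notes on the series. Of the compounds shown here, two have numbers so far. Compound 1 `CCOc1ccc(/N=C/c2c(-c3ccccc3)[n+]([O-])c3ccc(OC)cc3[n+]2[O-])cc1` gives in a functional assay on HepG2 cells (Homo sapiens) for inhibition, read by sulforhodamine B assay, with a stated time of 48 h (on this read-out higher numbers stand for weaker inhibition and lower numbers for stronger inhibition), a value of 0.77 ug/mL. Among the compounds with values here, compound 2 `COc1ccc(NC(=O)Nc2c(C)[n+]([O-])c3ccc(Cl)cc3[n+]2[O-])cc1` gives in this assay a value of 0.5 ug/mL, the lowest of the two numbers; the nearest is compound 1, and the gap between them lies within the scatter, so the two values show no order between these compounds.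

Compound 3 `COc1ccc(NC(=O)Nc2c(C)[n+]([O-])c3ccc(OC)cc3[n+]2[O-])cc1` has not been measured. It differs from compound 2 in one place: methoxy in place of chloro on an aromatic carbon. Within the data shown here, compound 1 already carries a methoxy group at this position, but the rest of its structure also differs from compound 2, so no clean step for this change exists among the measured compounds; all that is known is that compound 1 at 0.77 ug/mL and compound 2 at 0.5 ug/mL sit close together.

On that basis the step expected from this change, a 1.2-fold higher number from compound 2 to compound 3 (0.08 log units; within the scatter), is small and within the scatter, with no direction favoured. For compound 3 the expected value in this assay is 0.6 ug/mL, with a range from 0.25 ug/mL to 1.5 ug/mL.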

Compound 3, half-maximal inhibitory concentration: 6 ug/mL
The estimate for compound 3 lay 10-fold (1.00 log units) below the measured number; the whole stated range lies below it.
By their numbers in this assay, from the lowest: compounds 2 and 1 (each within the scatter of the next); then compound 3.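

In this assay, within the data shown here, this position proves sensitive to what it carries: on the core of compound 2, methoxy in place of chloro gives a large change (a 12-fold higher number from compound 2 to compound 3 (1.08 log units; beyond the scatter)), the first clean step for this exchange. The exchange itself is small in what can be counted, with one chlorine leaving, one carbon and one oxygen entering and one hydrogen-bond acceptor added, so a small change on this aromatic carbon is enough to produce a step of this size. The step holds for this one pair only, as compound 1 also carries methoxy here but differs from compound 2 elsewhere too, and no measurement on hand accounts for the size of the step.

On these data alone, with only chloro and methoxy seen on this core, it remains open whether the step follows the loss of chloro or the arrival of methoxy; a fluoro, methyl or hydroxy group at this place would help separate the two. As far as these compounds go, it also remains open whether the same exchange gives a step of similar size on the core of compound 1.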